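Replacing the anilino phenyl with a methoxypyridinyl group

The source may report more compounds than this note shows. Statements on the series, on what has been measured and on what is new or still open speak of the compounds shown alone.

Compound 1 `COc1cccc(F)c1-c1cccc2nc(N)oc12` gives 2800 nM in an assay on isolated protein for inhibition of ribosomal protein S6 kinase alpha-2 (Homo sapiens), with a stated time of 150 min; a higher number here means a weaker inhibitor, a lower number a stronger inhibitor. Among the measured compounds shown here, compound 2 `COc1cccc(F)c1-c1cccc2nc(Nc3ccccc3)oc12` gives 1000 nM in this assay, the lowest of the two numbers so far; the step of a 2.8-fold lower number from compound 1 to compound 2 (0.45 log units; beyond the scatter) is the only measured step. Compound 3 `COc1cccc(Nc2nc3cccc(-c4c(F)cccc4OC)c3o2)n1` carries 6-methoxypyridin-2-yl in place of phenyl on a nitrogen on an aromatic ring, anilino to (6-methoxypyridin-2-yl)amino. For the measured compounds named here, no measured step covers a swap of this kind; the one available step shows only that an aryl on this nitrogen lowers the number modestly. The step of a 1.4-fold lower number from compound 2 to compound 3 (0.15 log units; within the scatter) is therefore expected to stay within the scatter. The estimate for compound 3 is 700 nM, with a range from 200 nM to 3000 nM.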

Compound 3, half-maximal inhibitory concentration: 620 nM
The estimate for compound 3 lay 1.1-fold (0.05 log units) above the measured number, and the stated range covers the measured number.
By their numbers in this assay, from the lowest: compounds 3 and 2 (each within the scatter of the next); then compound 1.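

In this assay, the nitrogen on the aromatic ring accepts 6-methoxypyridin-2-yl as well as phenyl, with a 1.6-fold lower number from compound 2 to compound 3 (0.21 log units; within the scatter). The larger substituent, with its added ring nitrogen and methoxy, therefore gives no separable gain over phenyl, while the comparison with the hydrogen parent remains clear: a 4.5-fold lower number from compound 1 to compound 3 (0.65 log units; beyond the scatter). No evidence on hand bears on this result. The compounds shown leave open whether the methoxy group or the pyridine nitrogen contributes anything alone, as plain pyridin-2-yl would test. They also leave open whether a saturated group such as cyclohexyl can replace the aromatic ring on this nitrogen.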